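Trifluoromethoxy for Chloro on a Series Without Signal

This account rests on a few compounds, and the source may have more. Where it says the series, first, only, none or still open, it means among the compounds named here.

Compound 1 `CC(C)(C)Cc1csc(N)c1C(=O)c1ccc(Cl)cc1`, compound 2 `CC(C)(C)Cc1c(-c2ccc(F)cc2F)sc(N)c1C(=O)c1ccc(Cl)cc1` and compound 3 `CC(C)(C)Cc1c(-c2ccc(Cl)cc2)sc(N)c1C(=O)c1ccc(Cl)cc1` share one core and differ only in what sits on one aromatic carbon. In an assay on CHO cells for displacement of a labelled ligand from adenosine receptor A1 (Homo sapiens), read by scintillation counting, tested at 10 uM (a higher number here means more inhibition at the concentration tested (going by the name of the read-out), a lower number less inhibition), compound 1 gives 1%, compound 2 gives 1% and compound 3 gives 1%. The step of no change at the digits printed from compound 1 to compound 2 (within the scatter), the step of no change at the digits printed from compound 1 to compound 3 (within the scatter) and the step of no change at the digits printed from compound 2 to compound 3 (within the scatter) all lie within the scatter, so compound 3 stands level with both companions, nearest to compound 1 and furthest from compound 2 only at the digits shown.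

Compound 4 `CC(C)(C)Cc1c(-c2ccc(OC(F)(F)F)cc2)sc(N)c1C(=O)c1ccc(Cl)cc1` has not yet been measured. It differs from compound 3 by trifluoromethoxy in place of chloro on an aromatic carbon. Among the measured compounds shown here, the steps that bear on this change are the two that alter the same part of the molecule, no change at the digits printed from compound 1 to compound 3 (within the scatter) and no change at the digits printed from compound 2 to compound 3 (within the scatter), and neither moved the read-out beyond the scatter. For the measured compounds named here, no measured pair exchanges one group for another within the attached aromatic ring, so the new change is not covered directly. Both relevant steps are flat, and the data give no sign that the new group departs from that. The step of no change at the digits printed from compound 3 to compound 4 (within the scatter) is expected to be none beyond the scatter. Compound 4 is therefore estimated at 1% in this assay, between 0% and 10%.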

Compound 4, a percentage reported as inhibition, at one concentration (the size of the read-out at that concentration, not a potency): 1%
Beside the measured number, compound 4's estimate shows no gap at the digits printed; the measured number falls inside the stated range.
By their numbers in this assay, from the lowest: compounds 1, 2, 3 and 4 (each within the scatter of the next).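

Trifluoromethoxy in place of chloro, on an aromatic carbon para to a large group, gives no change at the digits printed from compound 3 to compound 4 (within the scatter) in this assay. Among the compounds shown here, the earlier steps only put a whole aryl group in place of hydrogen or swapped one aryl group for another, whereas this is the first exchange of one group for another on the attached ring itself, and the read-out stays flat even though the entering group is larger than chloro and brings a hydrogen-bond acceptor. No measurement at hand accounts for this flat step.

With every compound shown lying within the scatter of the others, the series gives no reference point with a clear signal, so it cannot show whether this position matters for the read-out at all. On these data alone, whether an amine or a carboxylic acid in place of trifluoromethoxy on this ring would raise the inhibition stays open, as does whether any change elsewhere on the shared core would do so.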